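Chloro to Methoxy on a Shared Core, Position Changed

The source may report more compounds than this note shows. Statements on the series, on what has been measured and on what is new or still open speak of the compounds shown alone.

Compound 1 `COc1ccc(-c2cn3ccnc3c(-c3ccc4ncn(C5CCCCC5)c4c3)n2)cc1` and compound 2 `Clc1ccc(-c2cn3ccnc3c(-c3ccc4ncn(C5CCCCC5)c4c3)n2)cc1` share one core and differ in a single place. Among the measured compounds shown here, in a functional assay on SF-268 cells (Homo sapiens) for inhibition, read by sulforhodamine B assay, with a stated time of 48 h, tested at 10 uM (a higher number here means more inhibition at the concentration tested (going by the name of the read-out), a lower number less inhibition), compound 1 gives 49.9%, while in this assay compound 2 gives 4.83%, the lower of the two numbers measured so far; the change of chloro in place of methoxy on an aromatic carbon brought a number 45.1 percentage points lower from compound 1 to compound 2 (beyond the scatter). Compound 3 `COc1ccccc1-c1cn2ccnc2c(-c2ccc3ncn(C4CCCCC4)c3c2)n1` has not yet been measured. It differs from compound 2 in one place: 2-methoxyphenyl in place of 4-chlorophenyl on an aromatic carbon. For the measured compounds named here, the only measured step that bears on this is that exchange of chloro and methoxy in the opposite direction, which was large, so a rise beyond the scatter is expected in this assay, though the group entering is 2-methoxyphenyl rather than the 4-methoxyphenyl of compound 1, so the full size of that step cannot be assumed. Compound 3 is therefore expected to give about 30%, within a range from 5% to 60%. The expected step is thus a number 25.2 percentage points higher from compound 2 to compound 3 (beyond the scatter).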

Compound 3, a percentage reported as inhibition, at one concentration (the size of the read-out at that concentration, not a potency): 8.04%
Estimate against measurement, compound 3: 22 percentage points above; the measured number falls inside the stated range.
By their numbers in this assay, from the lowest: compounds 2 and 3 (each within the scatter of the next); then compound 1.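

In this assay the shift from 4-methoxyphenyl to 2-methoxyphenyl gives a number 41.9 percentage points lower from compound 1 to compound 3 (beyond the scatter) and so shows that having a methoxy group on this phenyl ring is not enough to keep the reading of compound 1: where the methoxy sits matters too. The exchange of 4-chlorophenyl for 2-methoxyphenyl gives a number 3.2 percentage points higher from compound 2 to compound 3 (within the scatter) and leaves those two groups indistinguishable here, so among the three groups at this position only the 4-methoxyphenyl of compound 1 stands apart. Nothing at hand explains this difference.

Going by these compounds, whether an amine or a longer alkoxy chain in place of the methoxy group of compound 1 would hold the same reading stays open. These readings, at one concentration in one cell line, also leave potency open.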